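A few compounds are considered here, and "the series" means these few. Any claim that something is new, unique, unknown or untested is made for them only; others in the source may bear on it.

Measured compounds in a functional assay on CCRF-CEM cells (Homo sapiens) for inhibition, read by sulforhodamine B assay, with a stated time of 48 h; a lower number here means a stronger inhibitor of growth, a higher number a weaker inhibitor of growth:
compound 1 `CN1CCN(CCCOc2cccc3nc(Nc4ccc(Cl)c(C(F)(F)F)c4)ccc23)CC1` gives 1210 nM
compound 2 `CN1CCN(CCCOc2cccc3nc(Nc4cc(Cl)cc(Cl)c4)ccc23)CC1` gives 1780 nM

Among the compounds with values here, on these two numbers compound 2 stands at the higher end; its only neighbour is compound 1, and the single measured step, a 1.5-fold higher number from compound 1 to compound 2 (0.17 log units; within the scatter), lies within the scatter, so the two compounds cannot be ranked against each other in this assay.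

Compound 3 `CN1CCN(CCCOc2cccc3nc(Nc4cccc(Cl)c4)ccc23)CC1` differs from compound 2 in one place: hydrogen in place of chloro on an aromatic carbon. Within the data shown here, the one step on record, a 1.5-fold higher number from compound 1 to compound 2 (0.17 log units; within the scatter), exchanges one substituted aryl for another and keeps two substituents on that ring; it does not remove one. It therefore bears on the present change only loosely, showing that a rearrangement of halogen groups on this aryl left the number in this assay essentially where it was. Among the measured compounds shown here, no measured step covers the loss of a chloro group, so the expectation rests on the flatness seen so far. For compound 3 the step from its parent is expected to be a 1.4-fold higher number from compound 2 to compound 3 (0.15 log units; within the scatter), with no clear basis for a move beyond the scatter in either direction. Compound 3 is estimated at 2500 nM, within a range from 1000 nM to 6000 nM.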

Compound 3, concentration for 50% growth inhibition: 1680 nM
Compound 3: the middle estimate sits 1.5-fold (0.17 log units) above what was measured, and the stated range covers the measured number.
By their numbers in this assay, from the lowest: compounds 1, 3 and 2 (each within the scatter of the next).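

In this assay, within the data shown here, taking one chloro group off the 3,5-dichlorophenyl to leave 3-chlorophenyl is the first measured loss of a substituent on this aryl, and it gives a 1.1-fold lower number from compound 2 to compound 3 (0.03 log units; within the scatter), so at this place, meta to a chloro group, chloro and hydrogen cannot be told apart. The wider exchange, 3-chlorophenyl in place of 4-chloro-3-(trifluoromethyl)phenyl, gives a 1.4-fold higher number from compound 1 to compound 3 (0.14 log units; within the scatter), which puts all three aryl groups shown within the scatter of one another and means that neither the second chloro group nor the trifluoromethyl group can be shown to matter in this assay. Nothing on record offers an explanation for how closely these numbers sit.

As far as these compounds go, it remains open whether an unsubstituted phenyl, or a ring carrying a methoxy group, an amine or a carboxylic acid, would stay within the same scatter. The three compounds also share the rest of the structure, so they say nothing about a shorter or longer chain on the core.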